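Swapping nitro for methyl on the weakest of three inhibitors

The compounds below may be only part of what the source reports. "The series", "measured", "known", "first", "only" and "open" are said of these compounds alone.

Of the compounds shown here, three built on one shared core have been tested in a functional assay on ECa-109 cells (Homo sapiens) for inhibition, read by MTT assay, with a stated time of 72 h; a lower number here means a stronger inhibitor, a higher number a weaker inhibitor. Compound 1 `CC(C)c1ccc(-c2nc(SCc3cn(CC(=O)NC(=O)Nc4ccccn4)nn3)nc(Nc3ccc(Cl)cc3)c2C#N)cc1` gives 11200 nM. Compound 2 `CC(C)c1ccc(-c2nc(SCc3cn(CC(=O)NC(=O)Nc4ccccn4)nn3)nc(Nc3cccc([N+](=O)[O-])c3)c2C#N)cc1` gives 31300 nM. Compound 3 `Cc1ccc(Nc2nc(SCc3cn(CC(=O)NC(=O)Nc4ccccn4)nn3)nc(-c3ccc(C(C)C)cc3)c2C#N)cc1` gives 6700 nM. Compound 2 stands at the highest number of the three, with compound 1 nearest and compound 3 furthest; the steps of a 2.8-fold higher number from compound 1 to compound 2 (0.45 log units; beyond the scatter) and a 4.7-fold lower number from compound 2 to compound 3 (0.67 log units; beyond the scatter) are both beyond the scatter, so compound 2 is the weakest inhibitor of the set in this assay.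

Compound 4 `Cc1cccc(Nc2nc(SCc3cn(CC(=O)NC(=O)Nc4ccccn4)nn3)nc(-c3ccc(C(C)C)cc3)c2C#N)c1` has not yet been measured. It differs from compound 2 by methyl in place of nitro on an aromatic carbon. Going by the values given here, two measured steps bear on this change. The closest is a 4.7-fold lower number from compound 2 to compound 3 (0.67 log units; beyond the scatter), in which the nitro group also left and a methyl entered, though there the ring became 4-methylphenyl rather than 3-methylphenyl. The step of a 1.7-fold lower number from compound 1 to compound 3 (0.22 log units; within the scatter) shows that chloro and methyl on this ring give numbers within the scatter of each other, so the position of the methyl itself may matter little. A lowering of similar size is therefore expected here, estimated at a 3.9-fold lower number from compound 2 to compound 4 (0.59 log units; beyond the scatter). The estimate for compound 4 is 8000 nM, expected to lie between 3500 nM and 18000 nM.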

Compound 4, half-maximal inhibitory concentration: 7320 nM
Compound 4: the middle estimate sits 1.1-fold (0.04 log units) above what was measured; the range from low to high includes it.
By their numbers in this assay, from the lowest: compounds 3, 4 and 1 (each within the scatter of the next); then compound 2.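

In this assay the step of a 4.3-fold lower number from compound 2 to compound 4 (0.63 log units; beyond the scatter) isolates the change from nitro to methyl at one place on the ring, whereas the earlier step from compound 2 to compound 3 also moved the substituent to a different ring position. Moving the methyl has no readable effect, with a 1.1-fold higher number from compound 3 to compound 4 (0.04 log units; within the scatter) lying within the scatter, and a 1.5-fold lower number from compound 1 to compound 4 (0.18 log units; within the scatter) is also within the scatter, so compounds 1, 3 and 4 cannot be told apart here, while compound 2, with its 3-nitrophenyl group, is the only one that stands apart from all the others as the weakest. Nothing available explains why the nitro compound gives the highest number.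

As far as these compounds go, it remains open whether the nitro group itself or only its placement at this position goes with the weaker result, which a 4-nitrophenyl group could help separate. It is also unclear where a 3-aminophenyl or 3-carboxyphenyl group would fall, since the other groups shown on this ring carry only methyl or chloro.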